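The source may report more compounds than this note shows. Statements on the series, on what has been measured and on what is new or still open speak of the compounds shown alone.

Compound 1 `CC1=CCC[C@H]2[C@](C)(CC3=CC(=O)C=C(N[C@@H](C(=O)O)C(C)C)C3=O)[C@@H](C)CC[C@]12C` gives 85400 nM.
Compound 2 `CC(C)C[C@H](NC1=CC(=O)C=C(C(C)(C)C)C1=O)C(=O)O` gives a value that is a limit of the assay, > 200000 nM.
Compound 3 `CC(C)(C)C1=CC(=O)C=C(NCCC(=O)O)C1=O` also gives a limit of the assay, > 200000 nM.

All three were tested in an ADME assay on MRC5 cells (Homo sapiens) for cytotoxicity, read by MTT assay, with a stated time of 72 h; on this read-out lower numbers stand for stronger inhibition and higher numbers for weaker inhibition. Among the values shown, compound 1 stands alone as the only actual number; the other two compounds reach only (the limit of > 200000 nM in this assay, at which 2 of the 3 values shown sit), so no step between measured compounds can be read off, and nothing can be said about how compound 1 compares with compound 2 or compound 3 beyond the fact that their values are limits.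

Compound 4 `CC1=CCC[C@H]2[C@](C)(CC3=CC(=O)C=C(N[C@@H](C)C(=O)O)C3=O)[C@@H](C)CC[C@]12C` has not yet been measured in this assay. It keeps the whole core of compound 1 and changes only the side chain on the amine nitrogen: 1-carboxyethyl in place of 1-carboxy-2-methylpropyl on an amine nitrogen. This is a modest trimming of the side chain, two heavy atoms fewer, with the same hydrogen-bond donor and acceptor count and the same single stereocentre.

Among the compounds with values here, with no measured step of this kind to lean on, the expectation is a small change, if any, in this assay. Compound 4 is expected to sit near compound 1, with an estimated step of a 1.3-fold higher number from compound 1 to compound 4 (0.11 log units; within the scatter) lying within the scatter, and an estimated value of 110000 nM, in a range from 45000 nM to 200000 nM.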

Compound 4, half-maximal inhibitory concentration: 157000 nM
For compound 4 the middle estimate is 1.4-fold (0.15 log units) below the measured one; the range from low to high includes it.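

Within the data shown here, replacing 1-carboxy-2-methylpropyl with 1-carboxyethyl on the amine nitrogen gives the first step that can be read in this assay: a 1.8-fold higher number from compound 1 to compound 4 (0.26 log units; within the scatter). With the core of compound 1 kept whole, these two side chains therefore cannot be told apart on this read-out, so trimming this chain does not show a real effect on the cell result. Compound 2 and compound 3 each give a limit of the assay rather than a number, and no step involving them can be read: the limit of > 200000 nM in this assay, at which 2 of the 4 values shown sit.

Going by these compounds, only two side chains at this nitrogen can be compared, and both end in a carboxylic acid, so it remains open whether a longer chain, a benzyl group, or a methyl ester or primary amine in place of the acid would shift the number beyond the usual scatter. Among these compounds, it is equally open whether this pair of side chains would also give matching results on a core other than the one shared by compound 1 and compound 4.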